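Swapping a Chlorine-Bearing Ring for a Methyl-Bearing One

The compounds below may be only part of what the source reports. "The series", "measured", "known", "first", "only" and "open" are said of these compounds alone.

Among the compounds with values here, in a functional assay on HeLa cells (Homo sapiens) for cytotoxicity, read by MTT assay, with a stated time of 72 h (on this read-out higher numbers stand for weaker inhibition and lower numbers for stronger inhibition), compound 2 `Cc1cc(S(=O)(=O)/N=C(\N)n2nccc2-c2ccccc2)c(SCc2cccc(Cl)c2)cc1Cl` gives 10000 nM, the second highest of the three numbers known. Compound 3 `Cc1cc(-c2ccccc2)n(/C(N)=N/S(=O)(=O)c2cc(C)c(Cl)cc2SCc2cccc(Cl)c2)n1` gives 8000 nM, and the step of a 1.3-fold lower number from compound 2 to compound 3 (0.10 log units; within the scatter) lies within the scatter. Compound 1 `Cc1ccc(CSc2cc(Cl)c(C)cc2S(=O)(=O)/N=C(\N)n2nc(C)cc2-c2ccccc2)cc1` gives 62000 nM, the highest of the three. Compound 4 `Cc1cc(S(=O)(=O)/N=C(\N)n2nccc2-c2ccccc2)c(SCc2ccccc2C)cc1Cl` differs from compound 2 by 2-methylphenyl in place of 3-chlorophenyl on a saturated chain carbon bound to a sulfur. Within the data shown here, the one measured step at this place, a 7.8-fold lower number from compound 1 to compound 3 (0.89 log units; beyond the scatter), ran from a methyl-bearing ring to a chlorine-bearing ring and gave a lower number; compound 4 moves the other way, from chlorine back to methyl, though the names differ: 4-methylphenyl there, 2-methylphenyl here. For compound 4 a modest rise is therefore expected, a 4.0-fold higher number from compound 2 to compound 4 (0.60 log units; beyond the scatter). Compound 4 is estimated at 40000 nM, within a range of 12000 nM to 120000 nM.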

Compound 4, half-maximal inhibitory concentration: 17000 nM
Compound 4: middle estimate off by 2.4-fold (0.37 log units), on the high side, and the stated range covers the measured number.
By their numbers in this assay, from the lowest: compounds 3, 2 and 4 (each within the scatter of the next, the first and the last beyond it); then compound 1.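

In this assay, placing 2-methylphenyl where 3-chlorophenyl stood on a saturated chain carbon bound to a sulfur gives a 1.7-fold higher number from compound 2 to compound 4 (0.23 log units; within the scatter), so these two numbers cannot be told apart. The earlier swap between a methyl-bearing and a chlorine-bearing ring lay beyond the scatter, so a methyl-bearing ring at this place does not always separate from the 3-chlorophenyl compound. Nothing measured here explains why the two swaps read differently.

Still open, as far as these compounds go, is how a ring carrying an amine or a carboxylic acid would read at this place. A longer chain between the sulfur and the ring is equally untested among these compounds.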